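A few compounds are considered here, and "the series" means these few. Any claim that something is new, unique, unknown or untested is made for them only; others in the source may bear on it.

Three nucleoside analogues were examined in an assay on isolated protein for binding affinity to Equilibrative nucleoside transporter 1 (Homo sapiens); on this read-out higher numbers stand for weaker inhibition and lower numbers for stronger inhibition. Compound 1 `OC[C@H]1O[C@@H](n2cnc3c(SCC4CCCCC4)ncnc32)[C@H](O)[C@@H]1O` gives 1550 nM and stands lowest of the three numbers, so that on this read-out it is the strongest inhibitor of the set. Compound 2 `Nc1nc(SCc2ccccn2)c2ncn([C@@H]3O[C@H](CO)[C@@H](O)[C@H]3O)c2n1` gives 34700 nM, and compound 3 `CSc1ncnc2c1c(Br)cn2[C@@H]1O[C@H](CO)[C@@H](O)[C@H]1O` gives 115000 nM; both of these gaps from compound 1 lie well beyond the usual scatter of the measurement. No two of the measured compounds differ in only one place, so none of these gaps can be tied to a single change.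

Compound 4 `OC[C@H]1O[C@@H](n2cnc3c(CSc4ccc(I)cc4)ncnc32)[C@H](O)[C@@H]1O` has not yet been measured. It is derived from compound 1 by one change, (a group of 9 heavy atoms (7 carbon, 1 sulfur, 1 iodine; one six-membered aromatic ring of carbon only) in place of a group of 8 heavy atoms (7 carbon, 1 sulfur; one six-membered non-aromatic ring of carbon only), on an aromatic carbon). In the absence of any measured pair that isolates such a change, the size of the step cannot be drawn from the numbers shown; the account therefore rests on the change alone. A modest move toward stronger inhibition, within a wide range, is expected for compound 4, with a step of a 2.2-fold lower number from compound 1 to compound 4 (0.35 log units; beyond the scatter). Compound 4 is thus estimated to give 700 nM, the likely span running from 100 nM to 5000 nM.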

Compound 4, half-maximal inhibitory concentration: 69.2 nM
The estimate for compound 4 lay 10-fold (1.00 log units) above the measured number, outside the stated range (below it).
By their numbers in this assay, from the lowest: compound 4; then compound 1; then compound 2; then compound 3.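

In this assay, the replacement of (cyclohexylmethyl)sulfanyl on this aromatic carbon gives a 22-fold lower number from compound 1 to compound 4 (1.35 log units; beyond the scatter), the first gap in the set that can be tied to a single change. It shows that this position can respond strongly to the group it carries, and that a large step can come from a swap that barely alters the heavy-atom count. No measurement shown explains the step.

The aromatic ring, the iodine and the new arrangement of the sulfur all enter in one change, so their separate shares cannot be read. As far as these compounds go, it remains open whether an unsubstituted phenyl ring, or a chlorine or methoxy group in place of the iodine, would give a similar number, and whether the same change would carry over to other cores.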